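The source may report more compounds than this note shows. Statements on the series, on what has been measured and on what is new or still open speak of the compounds shown alone.

Measured in an ADME assay on Vero cells (Chlorocebus sabaeus) for cytotoxicity, read by MTT assay, with a stated time of 72 h; a lower number here means that less compound is tolerated, a higher number that more compound is tolerated:
- compound 1 `COc1c(N2CCN(CCC#N)C(C)C2)c(F)cc2c(=O)c(C(=O)O)cn(C3CC3)c12`: 500 ug/mL
- compound 2 `CO/N=C(\C)CN1CCN(c2c(F)cc3c(=O)c(C(=O)O)cn(C4CC4)c3c2OC)CC1C`: 49.6 ug/mL

Compound 2 stands as the lower of the two at 49.6 ug/mL. Compound 3 `COc1c(N2CCN(C/C(C)=N/O)C(C)C2)c(F)cc2c(=O)c(C(=O)O)cn(C3CC3)c12` differs from it by hydrogen in place of methyl on an oxygen, which also reads as methoxy to hydroxy. Among the measured compounds shown here, the only measured step, a 10-fold lower number from compound 1 to compound 2 (1.00 log units; beyond the scatter), replaces a different group, so it bears on this change only loosely. For the measured compounds named here, no measured step shows this exchange itself. In this assay, no step beyond the scatter is expected, only a slight lean towards a higher number. The expected step is a 1.6-fold higher number from compound 2 to compound 3 (0.21 log units; within the scatter). Compound 3 is estimated at 80 ug/mL, with an expected range of 30 ug/mL to 250 ug/mL.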

Compound 3, half-maximal cytotoxic concentration: 177 ug/mL
The estimate for compound 3 lay 2.2-fold (0.34 log units) below the measured number; the range from low to high includes it.
By their numbers in this assay, from the lowest: compound 2; then compound 3; then compound 1.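

In this assay, hydrogen in place of methyl on the oxygen bound to the double-bonded nitrogen gives a 3.6-fold higher number from compound 2 to compound 3 (0.55 log units; beyond the scatter), so this single-atom exchange at the end of the chain moves the number beyond the scatter. A gap to the nitrile-bearing chain remains, with a 2.8-fold lower number from compound 1 to compound 3 (0.45 log units; beyond the scatter), and the hydroxy compound falls short of that chain's number. Nothing measured here gives a reason for either step.

Only hydrogen and methyl are shown on that oxygen, so the reading with an ethyl group or a longer chain there remains open. On these data alone, whether the exchange gives a step of similar size on another core also remains open.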